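The source may report more compounds than this note shows. Statements on the series, on what has been measured and on what is new or still open speak of the compounds shown alone.

Three compounds that share one core and differ only in the substituted phenyl on an amine nitrogen have so far been measured in a functional assay (mast cells) for inhibition, with Rattus norvegicus as the target (a lower number here means that less compound is needed, a higher number that more compound is needed for the effect), with clear separation. Compound 1 `CC1CC/C(=N\Nc2ccccc2F)c2ncc(C(=O)O)c(=O)n21` gives 1200 nM there, compound 2 `CC1CC/C(=N\Nc2cccc(Br)c2)c2ncc(C(=O)O)c(=O)n21` gives 6700 nM there, and compound 3 `Cc1ccc(N/N=C2\CCC(C)n3c2ncc(C(=O)O)c3=O)cc1` gives 280 nM as the lowest of the three numbers. Compound 4 `CC1CC/C(=N\Nc2ccc(-c3ccccc3)cc2)c2ncc(C(=O)O)c(=O)n21` is still unmeasured. Its difference from compound 3 (phenyl in place of methyl on an aromatic carbon) is phenyl in place of methyl on an aromatic carbon, para to a large group.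

Going by the values given here, three measured steps bear on this change. The step of a 4.3-fold lower number from compound 1 to compound 3 (0.63 log units; beyond the scatter) is modest, the step of a 24-fold lower number from compound 2 to compound 3 (1.38 log units; beyond the scatter) is large, and the step of a 5.6-fold higher number from compound 1 to compound 2 (0.75 log units; beyond the scatter) is modest. Among the compounds with values here, none of the three compounds carries a phenyl at this place, so no step measures the change directly. The steps do show that the number moves beyond the scatter when this group changes, and both other groups give higher numbers than compound 3 does, with compound 2 at 6700 nM as the far end. A modest rise is therefore expected in this assay with the estimated step being a 2.9-fold higher number from compound 3 to compound 4 (0.46 log units; beyond the scatter) for this change. For compound 4 the estimated value is 800 nM with an expected range from 150 nM to 4000 nM in this measurement.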

Compound 4, half-maximal effective concentration: 4400 nM
Estimate against measurement, compound 4: 5.5-fold (0.74 log units) below, outside the stated range (above it).
By their numbers in this assay, from the lowest: compound 3; then compound 1; then compounds 4 and 2 (each within the scatter of the next).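

The earlier steps shown here changed the group and where it stands on the phenyl ring together, whereas this change keeps the place fixed, on an aromatic carbon para to a large group, and alters only what stands there. In this assay, phenyl in place of methyl gives a 16-fold higher number from compound 3 to compound 4 (1.20 log units; beyond the scatter) and so shows that this place alone can carry a large step, with compound 4 at 4400 nM within the scatter of compound 2 at 6700 nM despite a different group at a different place on the ring. Nothing measured on these compounds accounts for the rise, so its cause remains unexplained.

With only methyl and phenyl seen at this place, the compounds shown cannot tell whether the number climbs steadily as the group grows or whether the added aromatic ring itself matters. An ethyl, a methoxy or a pyridyl ring at the same place would separate these readings, and a carboxylic acid or an amine there would show how far the outcome depends on the kind of group rather than on its count of atoms.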